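The source may hold more compounds than are shown below. What is called first, only, known or untested is meant among the compounds shown, and "the series" means these compounds.

Compound 1 `CCOCCOC(=O)C(=O)Nc1nc(-c2cc(Cl)no2)cs1`: 6 mg/kg
Compound 2 `CCOC(=O)C(=O)Nc1nc(-c2cc(Br)no2)cs1`: 12 mg/kg
Compound 3 `CCOCCOC(=O)C(=O)Nc1nc(-c2cc(Br)no2)c(CC)s1`: 3 mg/kg

All three values come from a functional assay on the whole organism with Rattus norvegicus as the target; on this read-out lower numbers stand for an effect already at smaller amounts and higher numbers for an effect only at larger amounts of compound. Compound 1 lies in the middle of the three numbers, with compound 2 and compound 3 each within the scatter of it. The next step leads to compound 4 `CCOCCOC(=O)C(=O)Nc1nc(-c2cc(OCc3ccccc3)no2)cs1`, with benzyloxy in place of chloro on an aromatic carbon. Within the data shown here, no measured compound carries a benzyloxy group, and no step between measured compounds is available as a guide, so the expectation is weakly founded. A moderate shift towards larger doses is expected, starting from compound 1 at 6 mg/kg. The estimated change is a 2.5-fold higher number from compound 1 to compound 4 (0.40 log units; beyond the scatter). For compound 4 the estimate is 15 mg/kg, with an expected range of 4 mg/kg to 50 mg/kg.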

Compound 4, dose for half-maximal effect: 3.7 mg/kg
Compound 4: middle estimate off by 4.1-fold (0.61 log units), on the high side; the whole stated range lies above it.
By their numbers in this assay, from the lowest: compounds 3, 4, 1 and 2 (each within the scatter of the next, the first and the last beyond it).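

In this assay the aromatic carbon next to the ring nitrogen accepts benzyloxy in place of chloro, with the step staying within the scatter (a 1.6-fold lower number from compound 1 to compound 4 (0.21 log units; within the scatter)). Among these compounds, the earlier compounds carried only chloro or bromo here, so this is the first sign that a group with its own six-membered aromatic ring is compatible with this position. No measurement on hand explains this outcome.

Still open, as far as these compounds go, is how much the oxygen link and the aromatic ring each contribute. A methoxy group or an amine at this position would address that.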